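Chain Extension on the Ring Nitrogen of Compound 1

A few compounds are considered here, and "the series" means these few. Any claim that something is new, unique, unknown or untested is made for them only; others in the source may bear on it.

Two measured compounds share a core and differ both in the aryl group and in the substituent on the aromatic nitrogen. Compound 1 `CC[C@H](C1CC1)n1c(=O)c(C)nc2c(-c3ccc(Cl)cc3Cl)ccnc21` is tested in a functional assay for antagonist activity at corticotropin-releasing factor receptor 1 (Rattus norvegicus) (a lower number here means a stronger inhibitor, a higher number a weaker inhibitor), where compound 1 gives 8.2 nM. Compound 2 `CCC(C1CC1)n1c(=O)c(C)nc2c(-c3cc(Cl)c(OC)cc3OC)ccnc21` carries a different aryl group; in this assay compound 2 gives 3.4 nM. Compound 1 thus has the higher of the two numbers, and since the gap to compound 2 lies beyond the usual scatter, compound 1 is the weaker inhibitor of the pair.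

The unmeasured compound 3 `CCCC(C1CC1)n1c(=O)c(C)nc2c(-c3ccc(Cl)cc3Cl)ccnc21` keeps the aryl group of compound 1 and changes only the substituent on the aromatic nitrogen: 1-cyclopropylbutyl in place of 1-cyclopropylpropyl on an aromatic nitrogen. For the measured compounds named here, no measured pair shows what lengthening this chain does, so the data give no direct guide. The change adds a single carbon to a chain and alters nothing else, so the step in this assay is expected to be small, with no clear direction beyond the scatter. Compound 3 is therefore estimated at 10 nM, with a range from 3.5 nM to 30 nM. The expected step is a 1.2-fold higher number from compound 1 to compound 3 (0.09 log units; within the scatter).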

Compound 3, half-maximal inhibitory concentration: 4.3 nM
For compound 3 the middle estimate is 2.3-fold (0.37 log units) above the measured one; the measured number falls inside the stated range.
By their numbers in this assay, from the lowest: compounds 2, 3 and 1 (each within the scatter of the next, the first and the last beyond it).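

For the compounds shown here, the step of a 1.9-fold lower number from compound 1 to compound 3 (0.28 log units; within the scatter) is the first direct reading of chain length at this aromatic nitrogen, and it shows that in this assay 1-cyclopropylbutyl and 1-cyclopropylpropyl cannot be told apart, even though the step lies close to the edge of the scatter. This pair holds the aryl group fixed, which the earlier comparison of compound 1 with compound 2 could not do, but the change is not purely one of length: the leaving 1-cyclopropylpropyl of compound 1 has a defined stereocentre, whereas none is listed for the entering 1-cyclopropylbutyl of compound 3, so the two effects stay tied together. No measurement at hand offers a reason for the size of this step.

Going by these compounds, it remains open whether a longer chain such as 1-cyclopropylpentyl, or a chain ending in a hydroxyl group, would stay within the scatter of compound 1 or begin to move the number in this assay. Also open, on these data alone, are how each separate stereoisomer of compound 3 would behave and whether 1-cyclopropylbutyl would give a similar step when paired with the aryl group of compound 2.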